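The source may report more compounds than this note shows. Statements on the series, on what has been measured and on what is new or still open speak of the compounds shown alone.

Working notes on the series, all read in a functional assay on MKN-45 cells (Homo sapiens) for cytotoxicity (on this read-out higher numbers stand for weaker inhibition and lower numbers for stronger inhibition), throughout. Compound 1 `COc1ccc(S(=O)(=O)N2CCc3cccc(NS(=O)(=O)c4ccc(F)cc4)c32)cc1` gives 890 nM here, compound 2 `COC(=O)c1ccc(C(=O)Nc2cccc3c2N(S(=O)(=O)c2ccc(OC)cc2)CC3)cc1` gives 312 nM and compound 3 `COc1ccc(S(=O)(=O)N2CCc3cccc(NC(=O)c4ccc(F)cc4)c32)cc1` gives 45 nM as the lowest of the three numbers, with both gaps beyond the scatter. Compound 4 `COc1ccc(S(=O)(=O)N2CCc3cccc(NC(=O)c4ccccc4)c32)cc1` remains unmeasured. Against compound 3 it carries the change hydrogen in place of fluoro on an aromatic carbon (hydrogen in place of fluoro on an aromatic carbon, para to a large group).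

The closest evidence is the modest step of a 6.9-fold lower number from compound 2 to compound 3 (0.84 log units; beyond the scatter) (fluoro in place of methoxycarbonyl on an aromatic carbon). It concerns the same substituent. The large step of a 20-fold lower number from compound 1 to compound 3 (1.30 log units; beyond the scatter) (carbonyl in place of sulfonyl) bears only indirectly. Among the measured compounds shown here, no measured compound has hydrogen on that carbon, so the direction is weakly supported. A small rise in the number, near the edge of the scatter, is expected. The estimated step is a 1.8-fold higher number from compound 3 to compound 4 (0.25 log units; within the scatter). For compound 4 the expected value is 80 nM with 30 nM to 220 nM as its estimated range.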

Compound 4, half-maximal inhibitory concentration: 250 nM
For compound 4 the middle estimate is 3.1-fold (0.49 log units) below the measured one; the whole stated range lies below it.
By their numbers in this assay, from the lowest: compound 3; then compounds 4 and 2 (each within the scatter of the next); then compound 1.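

In this assay, among the compounds shown here, hydrogen in place of fluoro on this aromatic carbon, para to a large group, gives a 5.6-fold higher number from compound 3 to compound 4 (0.74 log units; beyond the scatter), so the single fluorine atom separates compound 3 from its unsubstituted partner by more than the scatter. Methoxycarbonyl and hydrogen at this carbon are not separated, with a 1.2-fold lower number from compound 2 to compound 4 (0.10 log units; within the scatter), which leaves fluoro alone among the three groups, while the benzoyl amide still holds a 3.6-fold lower number from compound 1 to compound 4 (0.55 log units; beyond the scatter) against the (4-fluorophenyl)sulfonyl compound. No measurement at hand accounts for the effect of fluoro at this carbon.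

Going by these compounds, whether chloro, methyl or an amine on this carbon would read with fluoro or with hydrogen stays open. So does whether the fluoro to hydrogen step holds when the amide carbonyl is replaced by sulfonyl.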